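A few compounds are considered here, and "the series" means these few. Any claim that something is new, unique, unknown or untested is made for them only; others in the source may bear on it.

Measured compounds:
- compound 1 `O=C(Nc1ccc(Oc2ccnc3[nH]ccc23)cc1)c1cn(-c2ccc(Cl)cc2)c2ccccc2c1=O`: 650 nM
- compound 2 `O=C(Nc1ccc(Oc2ccnc3[nH]ccc23)cc1)c1cn(-c2ccc(F)c(Cl)c2)c2ccccc2c1=O`: 4810 nM

Within the data shown here, in a functional assay on A549 cells (Homo sapiens) for inhibition, read by MTT assay, with a stated time of 72 h (a higher number here means a weaker inhibitor, a lower number a stronger inhibitor), compound 2 gives the highest of the two numbers, and its only neighbour is compound 1, which gives 650 nM. Compound 3 `COc1ccc(-n2cc(C(=O)Nc3ccc(Oc4ccnc5[nH]ccc45)cc3)c(=O)c3ccccc32)cc1` differs from compound 2 in one place: 4-methoxyphenyl in place of 3-chloro-4-fluorophenyl on an aromatic nitrogen. Among the measured compounds shown here, the one measured step at this same position, a 7.4-fold higher number from compound 1 to compound 2 (0.87 log units; beyond the scatter), shows that swapping the group on this aromatic nitrogen can shift this assay well beyond the scatter. A step back toward the single-substituent phenyl is therefore expected to lower the number, a 3.2-fold lower number from compound 2 to compound 3 (0.51 log units; beyond the scatter), and compound 3 is estimated at 1500 nM with a range from 400 nM to 6000 nM.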

Compound 3, half-maximal inhibitory concentration: 4980 nM
Beside the measured number, compound 3's estimate is 3.3-fold (0.52 log units) below it; the measured number falls inside the stated range.
By their numbers in this assay, from the lowest: compound 1; then compounds 2 and 3 (each within the scatter of the next).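

In this assay, 4-methoxyphenyl in place of 3-chloro-4-fluorophenyl gives a 1.0-fold higher number from compound 2 to compound 3 (0.02 log units; within the scatter) and so no separation between these two different groups on the aromatic nitrogen. Methoxy in place of chloro gives a 7.7-fold higher number from compound 1 to compound 3 (0.88 log units; beyond the scatter) on the same phenyl, so compound 1 stands apart from both others, and compound 3 shows that a single substituent on this phenyl does not by itself give the low number of compound 1. Nothing available explains this difference. From the compounds shown here alone, how bromo, an amine or a carboxylic acid in place of the chloro of compound 1 would read remains open.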